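The source may report more compounds than this note shows. Statements on the series, on what has been measured and on what is new or still open speak of the compounds shown alone.

Measured compounds:
Compound 1, `CS(=O)(=O)c1ccc(C(=O)N2CCC(n3cncc3-c3ccc(OS(=O)(=O)c4cccc5cnccc45)cc3)CC2)cc1`, 25 nM
Compound 2, `O=C(c1ccc([N+](=O)[O-])cc1)N1CCC(n2cncc2-c2ccc(OS(=O)(=O)c3cccc4cnccc34)cc2)CC1`, 1.49 nM
Compound 3, `CS(=O)(=O)c1ccc(C(=O)N2CCN(c3cc(=O)[nH]c(=O)n3Cc3ccc(OS(=O)(=O)c4cccc5cnccc45)cc3)CC2)cc1`, 44 nM

All three were tested in an assay on HEK293 cells for antagonist activity at P2X purinoceptor 7 (Homo sapiens), read by fluorescence, with a stated time of 2 h; a lower number here means a stronger inhibitor, a higher number a weaker inhibitor. Compound 1 and compound 2 share one core and differ in a single spot: nitro in place of methylsulfonyl on an aromatic carbon. That change gave a 17-fold lower number from compound 1 to compound 2 (1.22 log units; beyond the scatter). Compound 3 sits on a different core; how the two cores differ is not broken down here. Its value in this assay is the highest of the three, though the gap to compound 1 lies within the scatter, while the gap to compound 2 is beyond it.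

Compound 4, `O=C(c1ccc([N+](=O)[O-])cc1)N1CCN(c2cc(=O)[nH]c(=O)n2Cc2ccc(OS(=O)(=O)c3cccc4cnccc34)cc2)CC1`, has not yet been measured. It is built from compound 3 by the same change: nitro in place of methylsulfonyl on an aromatic carbon. For the measured compounds named here, because the earlier step is a 17-fold lower number from compound 1 to compound 2 (1.22 log units; beyond the scatter), a lowering of similar kind is expected here, somewhat tempered since the core is not the same and only one earlier example exists. Compound 4 is therefore expected to show an 11-fold lower number from compound 3 to compound 4 (1.04 log units; beyond the scatter). Compound 4 is estimated to give 4 nM in this assay, with a likely range from 1 nM to 15 nM.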

Compound 4, half-maximal inhibitory concentration: 27 nM
Compound 4: middle estimate off by 6.8-fold (0.83 log units), on the low side; measured number above the stated range.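

The size of this change does not carry from one core to the other. In this assay, the new step is a 1.6-fold lower number from compound 3 to compound 4 (0.21 log units; within the scatter), so on this core the nitro and methylsulfonyl compounds cannot be told apart. Set beside the earlier step, the result of the same swap clearly depends on the core: the same change on two cores in this assay, a 17-fold lower number (1.22 log units; beyond the scatter) from compound 1 to compound 2 and a 1.6-fold lower number (0.21 log units; within the scatter) from compound 3 to compound 4, 10-fold (1.01 log units) apart, beyond the scatter of two such steps This shows that, across these two cores, one step cannot be relied on to predict the other, but with only one pair on each core it does not show which part of the core is responsible or what would happen on a third core.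

The compounds shown leave open whether other groups on the same aromatic carbon, such as a nitrile or a carboxylic acid, would follow the large step seen on the core of compound 1 or the step within the scatter seen on the core of compound 3. They also leave open which feature separating the two cores accounts for the difference.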